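Hydrazones of a Naphthyloxyacetyl Core: Towards a Bromophenyl Analogue

A few compounds are considered here, and "the series" means these few. Any claim that something is new, unique, unknown or untested is made for them only; others in the source may bear on it.

Compound 1 `O=C(COc1cccc2ccccc12)N/N=C/c1c(O)ccc2ccccc12` in an ADME assay on HEL cells (Homo sapiens) for cytotoxicity; on this read-out lower numbers stand for higher toxicity in this test and higher numbers for lower toxicity in this test: 4 ug/mL
Compound 2 `C/C(=N\NC(=O)COc1cccc2ccccc12)c1ccc(O)cc1O` in this assay: > 100 ug/mL

Compound 1 gives 4 ug/mL in this assay. For compound 2 the result > 100 ug/mL is only a limit of the test, not a number, and this is where compound 2 stands: at the limit of > 100 ug/mL in this assay, at which 1 of the 2 values shown sits. How far beyond that limit compound 2 actually lies is not known.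

Compound 3 `C/C(=N\NC(=O)COc1cccc2ccccc12)c1ccc(Br)cc1` is still to be measured. It differs from compound 2 by 4-bromophenyl in place of 2,4-dihydroxyphenyl on a carbon with a double bond to nitrogen. Among the compounds with values here, no step between measured compounds covers this change, so its size cannot be read from a measured pair. Since compound 1, lacking the hydroxyl groups, gives 4 ug/mL, a move toward lower numbers beyond the scatter is expected, and the estimated step is an at least 2.5-fold lower number from compound 2 to compound 3 (0.39 log units; beyond the scatter). Compound 3 is therefore expected to give 40 ug/mL, with a range from 10 ug/mL to 100 ug/mL.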

Compound 3, minimum cytotoxic concentration: 20 ug/mL
Beside the measured number, compound 3's estimate is 2.0-fold (0.30 log units) above it; the measured number falls inside the stated range.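

With 4-bromophenyl in place of 2,4-dihydroxyphenyl on a carbon with a double bond to nitrogen, this assay gives an at least 5.0-fold lower number from compound 2 to compound 3 (0.69 log units; beyond the scatter). Within the data shown here, this is the first step read at this position, and it shows that the group carried there can move this read-out beyond the scatter, even with the rest of the structure unchanged. The size of the step is only a lower bound, since the result for compound 2 is a limit and not a number: the limit of > 100 ug/mL in this assay, at which 1 of the 3 values shown sits.

The change removes the hydroxyl groups and brings in bromine at once, so the compounds shown do not separate the two contributions. On these data alone, whether a plain phenyl, a 4-hydroxyphenyl or a 4-chlorophenyl on the same carbon would fall nearer compound 2 or compound 3 remains open.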